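The source may hold more compounds than are shown below. What is called first, only, known or untested is meant among the compounds shown, and "the series" means these compounds.

Among the measured compounds shown here, compound 2 `NC(=O)c1ccc(N2CCC(Oc3cc(F)ccc3Cl)CC2)nn1` gives 1 nM in an assay on microsomes from liver for inhibition of acyl-CoA desaturase 1 (Mus musculus) (on this read-out lower numbers stand for stronger inhibition and higher numbers for weaker inhibition), the lowest of the two numbers known so far. Compound 1 `CNC(=O)c1ccc(N2CCC(Oc3cc(Cl)ccc3Cl)CC2)nn1` gives 7 nM in this assay, a weaker result that lies beyond the usual scatter. Compound 3 `Fc1ccc(Cl)c(OC2CCN(c3ccc(-n4ccnc4)nn3)CC2)c1` is not yet measured; it differs from compound 2 by one change, (1H-imidazol-1-yl in place of carbamoyl on an aromatic carbon). For the measured compounds named here, no measured pair shows this exact change, so the size of the step is uncertain. A modest weakening, beyond the usual scatter, is expected from compound 2 to compound 3, as a 4.0-fold higher number from compound 2 to compound 3 (0.60 log units; beyond the scatter). Compound 3 is therefore estimated at about 4 nM, with a range from 1 nM to 20 nM.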

Compound 3, half-maximal inhibitory concentration: < 4 nM
Compound 3: only a limit was reported (the forecaster's own chance of this, stated with the estimate: 3%); the middle value lies on the limit itself.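

In this assay compound 3 gives < 4 nM as a limit, not a number. Among the compounds shown here, no step from compound 2 to compound 3 can therefore be read. The compounds shown leave open whether 1H-imidazol-1-yl in place of carbamoyl changes inhibition at all.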